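Swapping a Naphthyl Ether for a Chlorophenyl Ether

The compounds below may be only part of what the source reports. "The series", "measured", "known", "first", "only" and "open" are said of these compounds alone.

Compound 1 `Cc1ccc(CC(C)C(=O)N2CCN(c3ccc(C(F)(F)F)cc3[C@@H](N)CC(C)C)CC2)cc1C` gives 240 nM in an assay on HEK293 cells for displacement of a labelled ligand from Melanocortin receptor 4 (Homo sapiens); on this read-out lower numbers stand for stronger inhibition and higher numbers for weaker inhibition.
Compound 2 `CC(C)C[C@H](N)c1cc(C(F)(F)F)ccc1N1CCN(C(=O)CNc2ccccc2)CC1` gives 3600 nM in this assay.
Compound 3 `CC(C)C[C@H](N)c1cc(C(F)(F)F)ccc1N1CCN(C(=O)COc2cccc3ccccc23)CC1` gives 2600 nM in this assay.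

Compound 3 has the second highest of the three numbers; compound 2 sits within the scatter of it, while an 11-fold higher number from compound 1 to compound 3 (1.03 log units; beyond the scatter) separates it clearly from compound 1. Compound 4 `CC(C)C[C@H](N)c1cc(C(F)(F)F)ccc1N1CCN(C(=O)COc2ccc(Cl)cc2)CC1` keeps the same core and differs only at the ether end: 4-chlorophenyl in place of naphthalen-1-yl on an oxygen on a saturated carbon. Of the measured steps, a 1.4-fold lower number from compound 2 to compound 3 (0.14 log units; within the scatter) is the one that alters this part of the molecule, and it stayed within the scatter. The large change an 11-fold higher number from compound 1 to compound 3 (1.03 log units; beyond the scatter) replaced the whole group on the carbonyl carbon, so it says little here. For compound 4 a step within the scatter is therefore expected, a 1.2-fold higher number from compound 3 to compound 4 (0.06 log units; within the scatter), giving an estimated 3000 nM with a range from 1000 nM to 9000 nM.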

Compound 4, inhibition constant: 2900 nM
Beside the measured number, compound 4's estimate is 1.0-fold (0.01 log units) above it; low and high end bracket the measured number.
By their numbers in this assay, from the lowest: compound 1; then compounds 3, 4 and 2 (each within the scatter of the next).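

In this assay, the two-ring naphthalen-1-yl gives way to the one-ring 4-chlorophenyl, with fewer heavy atoms, and the step stays within the scatter (a 1.1-fold higher number from compound 3 to compound 4 (0.05 log units; within the scatter)), so this position shows no readable response to this change. The 4-chlorophenoxy and anilino groups also read alike (a 1.2-fold lower number from compound 2 to compound 4 (0.09 log units; within the scatter)), while the gap to the 1-(3,4-dimethylbenzyl)ethyl group remains beyond the scatter (a 12-fold higher number from compound 1 to compound 4 (1.08 log units; beyond the scatter)). Nothing available explains these results.

Which part of the 1-(3,4-dimethylbenzyl)ethyl group accounts for that gap stays open. So does how an amine or a carboxylic acid would read in place of 4-chlorophenyl.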